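This account rests on a few compounds, and the source may have more. Where it says the series, first, only, none or still open, it means among the compounds named here.

Going by the values given here, in a toxicity assay on MT4 cells (Homo sapiens) for cytotoxicity, read by MTT assay, with a stated time of 5 days (a lower number here means that less compound is tolerated, a higher number that more compound is tolerated), compound 3 `Cc1cc(-c2cccc3cc[nH]c23)cc(C)c1Nc1ccnc(Nc2ccc(C#N)cc2)n1` gives 1000 nM, the lowest of the numbers so far. Compound 1 `Cc1cc(-c2cccs2)cc(C)c1Nc1ccnc(Nc2ccc(C#N)cc2)n1` gives 10000 nM, and compound 2 `Cc1cc(-c2cc3ccccc3s2)cc(C)c1Nc1ccnc(Nc2ccc(C#N)cc2)n1` gives 138000 nM. Compound 4 `Cc1ccc(-c2cc(C)c(Nc3ccnc(Nc4ccc(C#N)cc4)n3)c(C)c2)s1` is still unmeasured. It carries 5-methylthiophen-2-yl in place of 1H-indol-7-yl on an aromatic carbon. The closest guide is the modest swap of thiophen-2-yl for 1H-indol-7-yl, a 10-fold lower number from compound 1 to compound 3 (1.00 log units; beyond the scatter), which is read here in reverse. Two large steps, a 14-fold higher number from compound 1 to compound 2 (1.14 log units; beyond the scatter) and a 140-fold lower number from compound 2 to compound 3 (2.14 log units; beyond the scatter), show that the number can move widely with the group at this place. A modest rise is therefore expected, an estimated 10-fold higher number from compound 3 to compound 4 (1.00 log units; beyond the scatter). The expected value for compound 4 is 10000 nM, with an estimated range from 3000 nM to 40000 nM.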

Compound 4, half-maximal cytotoxic concentration: 28000 nM
Compound 4: the middle estimate sits 2.8-fold (0.45 log units) below what was measured, within the range that was stated.
By their numbers in this assay, from the lowest: compound 3; then compound 1; then compound 4; then compound 2.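

In this assay a single added methyl on the thiophen-2-yl group already moves the number (a 2.8-fold higher number from compound 1 to compound 4 (0.45 log units; beyond the scatter)), so a small change on this ring counts, not only a swap of whole ring groups. The 5-methylthiophen-2-yl group still sits apart from both larger groups (a 28-fold higher number from compound 3 to compound 4 (1.45 log units; beyond the scatter); a 4.9-fold lower number from compound 2 to compound 4 (0.69 log units; beyond the scatter)). Nothing measured here explains these shifts. Going by these compounds, whether a chlorine, a methoxy group or an amine in place of that methyl would move the number the same way remains open.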